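The compounds below may be only part of what the source reports. "The series", "measured", "known", "first", "only" and "open" are said of these compounds alone.

Working notes on a set of glycosylated esters sharing one core, all tested in a functional assay on A2780 cells (Homo sapiens) for cytotoxicity, read by MTT assay, with a stated time of 4 days; a lower number here means a stronger inhibitor, a higher number a weaker inhibitor. Compound 1 `C[C@]1(O)C[C@@H](OC(=O)/C=C/c2ccccc2)[C@@H]2C=CO[C@@H](O[C@@H]3O[C@H](CO)[C@@H](O)[C@H](O)[C@H]3O)[C@@H]21` returns only a limit of this assay, > 10000 nM. Compound 2 `COc1cc(C(=O)O[C@@H]2C[C@](C)(O)[C@H]3[C@H](O[C@@H]4O[C@H](CO)[C@@H](O)[C@H](O)[C@H]4O)OC=C[C@H]32)ccc1O[C@@H]1O[C@H](CO)[C@@H](O)[C@H](O)[C@H]1O` likewise returns a limit, > 10000 nM. Compound 3 `COc1cc(C(=O)O[C@@H]2C[C@](C)(O)[C@H]3[C@H](O[C@@H]4O[C@H](CO)[C@@H](O)[C@H](O)[C@H]4O)OC=C[C@H]32)cc(OC)c1O[C@@H]1O[C@@H](C)[C@H](O)[C@@H](O)[C@H]1O` also returns a limit, > 10000 nM. Going by the values given here, compound 1 therefore stands with the others at the limit of > 10000 nM in this assay, at which 3 of the 3 values shown sit, and no step between the measured compounds can be sized or ordered. The untested compound 4 `C[C@]1(O)C[C@@H](OC(=O)CCc2cc(O)ccn2)[C@@H]2C=CO[C@@H](O[C@@H]3O[C@H](CO)[C@@H](O)[C@H](O)[C@H]3O)[C@@H]21` differs from compound 1 by 2-(4-hydroxypyridin-2-yl)ethyl in place of 2-phenylethenyl on a carbonyl carbon. Since every value in hand is a limit, no direction can be read from the series; the step is expected to stay within the scatter, estimated as a step that the limit leaves unreadable from compound 1 to compound 4. Compound 4 is expected to give 20000 nM, between 5000 nM and 100000 nM, most probably again as a limit.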

Compound 4, half-maximal inhibitory concentration: > 10000 nM
Compound 4: a limit, no number; the forecaster's own chance of this, stated with the estimate: 85%; the middle value lies beyond the limit too.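

Going by these compounds alone, compound 1 and compound 4 both return only a limit, so no step between them can be read. The compounds shown leave open whether any ester on the shared core gives a measurable value rather than a limit.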